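Cytotoxicity notes on a lactam-bearing peptidomimetic series

The source may report more compounds than this note shows. Statements on the series, on what has been measured and on what is new or still open speak of the compounds shown alone.

Compound 1 `O=C[C@H](C[C@@H]1CCNC1=O)NC(=O)[C@H](CC1CC1)NC(=O)OCc1ccccc1` carries a formyl group at the chain end. In an ADME assay on Vero C1008 cells (Chlorocebus sabaeus) for cytotoxicity, read by luminescence and CellTiter-Glo, with a stated time of 24 h (on this read-out lower numbers stand for higher toxicity in this test and higher numbers for lower toxicity in this test), compound 1 gives > 200000 nM, which is a limit of the assay and not a number. Compound 2 `O=C(N[C@@H](CC1CC1)C(=O)N[C@@H](C[C@@H]1CCNC1=O)C(O)S(=O)(=O)O)OCc1ccccc1` carries hydroxy(sulfo)methyl in place of formyl. In this assay compound 2 also gives > 200000 nM, again a limit of the assay. As far as these compounds go, the step from compound 1 to compound 2 reads a step that the two limits leave unreadable from compound 1 to compound 2, so its size stays unknown. Compound 2 therefore stands at the limit that both measured values share, (the limit of > 200000 nM in this assay, at which 2 of the 2 values shown sit).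

Compound 3 `C[C@H](OC(=O)N[C@@H](CC1CC1)C(=O)N[C@@H](C[C@@H]1CCNC1=O)C(O)S(=O)(=O)O)c1ccccc1` differs from compound 2 by methyl in place of hydrogen on a saturated chain carbon bound to an aromatic carbon and an oxygen next to a carbonyl group. For the measured compounds named here, no measured step touches this site: the only measured step, from compound 1 to compound 2, concerns another position and is unreadable anyway. With nothing pointing to a change beyond the scatter, the expectation for compound 3 in this assay is that it again reaches the assay limit. Compound 3 is expected at 200000 nM, within 100000 nM to 400000 nM. The step from compound 2 to compound 3 is accordingly estimated as a number no higher from compound 2 to compound 3 (the limit leaves the size open), essentially none.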

Compound 3, half-maximal cytotoxic concentration: > 200000 nM
Compound 3 gave a limit, no number; the forecaster's own chance of this, stated with the estimate: 85%; the middle value lies on the limit itself.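

Compound 3 gives > 200000 nM in this assay, a limit of the assay and not a number, so neither the step from compound 1 to compound 2 nor the step from compound 2 to compound 3 can be read: the limit of > 200000 nM in this assay, at which 3 of the 3 values shown sit.

The compounds shown leave open whether either change, hydroxy(sulfo)methyl for formyl or methyl for hydrogen, alters cytotoxicity in this assay, and at what concentration any of the three compounds would register a numerical value.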